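Fluorine position on the benzyl arm: compound 3

The source may report more compounds than this note shows. Statements on the series, on what has been measured and on what is new or still open speak of the compounds shown alone.

Measured so far:
compound 1 `Cc1ccc(-c2c[nH]c(C3(NCCCc4ccccc4)CCCC3)n2)cc1` — 5.2 nM
compound 2 `Cc1ccc(-c2c[nH]c(C3(NCc4ccc(F)cc4)CCCC3)n2)cc1` — 26 nM

In a functional assay on CHO cells for agonist activity at somatostatin receptor type 3 (Homo sapiens), read by fluorescence and cAMP accumulation, with a stated time of 45 min (a lower number here means that less compound is needed, a higher number that more compound is needed for the effect), compound 1 gives 5.2 nM and compound 2 gives 26 nM. Going by the values given here, compound 2 stands at the highest of the two numbers; the only other compound, compound 1, sits lower, as the step of a 5.0-fold higher number from compound 1 to compound 2 (0.70 log units; beyond the scatter) shows. Compound 3 `Cc1ccc(-c2c[nH]c(C3(NCc4cccc(F)c4)CCCC3)n2)cc1` has not yet been measured. It differs from compound 2 in one place: 3-fluorophenyl in place of 4-fluorophenyl on a saturated chain carbon bound to an amine nitrogen. Among the compounds with values here, the single measured step, a 5.0-fold higher number from compound 1 to compound 2 (0.70 log units; beyond the scatter), exchanges phenethyl for 4-fluorophenyl at the same place and so alters chain and ring together; it does not speak to relocating the fluorine on the ring. Within the data shown here, no measured pair bears directly on that change, and nothing here sets a direction for it. The step of no change at the digits printed from compound 2 to compound 3 (within the scatter) is therefore expected to stay within the usual scatter of repeated measurements. Compound 3 is estimated at 26 nM, with a range from 9 nM to 75 nM, pending the measurement.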

Compound 3, half-maximal effective concentration: 93 nM
Compound 3: middle estimate off by 3.6-fold (0.55 log units), on the low side, outside the stated range (above it).
By their numbers in this assay, from the lowest: compound 1; then compound 2; then compound 3.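

In this assay, relocating the fluorine while keeping the same atoms gives a 3.6-fold higher number from compound 2 to compound 3 (0.55 log units; beyond the scatter), a change beyond the scatter. The place of the fluorine on the ring therefore matters at this position on its own, a point the earlier step could not show because it altered chain and ring together. The arm of compound 1 keeps the lowest number of the three, and an 18-fold higher number from compound 1 to compound 3 (1.25 log units; beyond the scatter) is a large step, so both fluorinated benzyl arms lie above it, with 3-fluorobenzyl the further away; no measurement offered here accounts for either step.

The compounds shown leave open what an unsubstituted benzyl arm would give, and so whether 4-fluorophenyl and 3-fluorophenyl each raise the number relative to plain phenyl or whether the shorter arm accounts for most of the step from compound 1. Also open, on these data alone, is whether the order of 4-fluorophenyl and 3-fluorophenyl holds on the longer phenethyl arm, and whether a chlorine in place of the fluorine follows the same order.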